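Swapping dimethylamino for piperidin-1-yl on compound 1

A few compounds are considered here, and "the series" means these few. Any claim that something is new, unique, unknown or untested is made for them only; others in the source may bear on it.

Compound 1 `Cc1ccc(-c2nc3ccccc3s2)cc1NC(=O)c1cc([N+](=O)[O-])c(N(C)C)cc1Cl` gives > 25000 nM as its value
Compound 2 `O=C(Nc1nc2c(Cl)cccc2s1)c1cc([N+](=O)[O-])ccc1Cl` gives > 27000 nM as its value
Compound 3 `Cc1cc(NC(=O)c2cc([N+](=O)[O-])ccc2Cl)cc(-c2nc3ccccc3o2)c1O` gives > 25000 nM as its value

These three values come from an ADME assay on HEK293 cells (Homo sapiens) for cytotoxicity, with a stated time of 72 h (on this read-out lower numbers stand for an effect already at smaller amounts and higher numbers for an effect only at larger amounts of compound), and each of them is a limit of the assay, not a number.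

Compound 1 stands at > 25000 nM in this assay and this is a limit. Within the data shown here, the same holds for compound 2 and compound 3, so the measured set offers no number to compare and no step between measured compounds.

Among the measured compounds shown here, compound 4 `Cc1ccc(-c2nc3ccccc3s2)cc1NC(=O)c1cc([N+](=O)[O-])c(N2CCCCC2)cc1Cl` keeps the core of compound 1 but carries piperidin-1-yl in place of dimethylamino on an aromatic carbon, ortho to a nitro group and meta to a chloro group piperidin-1-yl in place of dimethylamino on an aromatic carbon as the only change.

With only limits to go on, no step beyond the usual scatter is expected in this assay and no direction can be given. The estimated change is a number no higher from compound 1 to compound 4 (the limit leaves the size open) in this expectation. Compound 4 is expected at 25000 nM with an estimated range from 12000 nM to 50000 nM in this assay and a report as a limit is likely.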

Compound 4, half-maximal effective concentration: > 25000 nM
Compound 4: no number, only a limit; the forecaster's own chance of this, stated with the estimate: 75%; the middle value lies on the limit itself.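

Compound 1 and compound 4 are both reported only as limits, so no step between them can be read: the limit of > 25000 nM in this assay, at which 3 of the 4 values shown sit.

The compounds shown leave open whether piperidin-1-yl in place of dimethylamino changes the value at all, and where the true value of any of them lies.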